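Swapping a Ring Group for Hydrogen on Two Cores

The source may report more compounds than this note shows. Statements on the series, on what has been measured and on what is new or still open speak of the compounds shown alone.

Measured so far in a functional assay on MDA-MB-231 cells (Homo sapiens) for cytotoxicity, read by MTT assay, with a stated time of 72 h; a higher number here means a weaker inhibitor, a lower number a stronger inhibitor:
Compound 1 `N=C(Nc1ccccc1)c1cc2c(-c3ccccc3)n[nH]c2c(NC2CCCCC2)n1` gives 1710 nM.
Compound 2 `CN1CCN(c2ccc(NC(=N)c3cc4c(-c5ccccc5)n[nH]c4c(NC4CCCCC4)n3)cc2)CC1` gives 1500 nM.
Compound 3 `COc1ccc(Cn2ncc3cc(C(=N)Nc4ccc(N5CCN(C)CC5)cc4)ncc32)cc1` gives 5700 nM.

Compound 2 and compound 1 share one core and differ in a single place, (hydrogen in place of 4-methylpiperazin-1-yl on an aromatic carbon); this gave a 1.1-fold higher number from compound 2 to compound 1 (0.06 log units; within the scatter). Compound 3 carries the same side group on a different core; how the two cores differ is not broken down here. Its value in this assay lies beyond the scatter from both compound 1 and compound 2, so compound 3 is the weakest of the three.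

Compound 4 `COc1ccc(Cn2ncc3cc(C(=N)Nc4ccccc4)ncc32)cc1` has not yet been measured. It relates to compound 3 as compound 1 relates to compound 2: hydrogen in place of 4-methylpiperazin-1-yl on an aromatic carbon. The two places match word for word, so this is the same change made on a different core. Resting on the step of a 1.1-fold higher number from compound 2 to compound 1 (0.06 log units; within the scatter) alone, compound 4 is expected to show a 1.1-fold higher number from compound 3 to compound 4 (0.04 log units; within the scatter). Compound 4 is therefore estimated at 6200 nM, plausibly between 3000 nM and 13000 nM.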

Compound 4, half-maximal inhibitory concentration: 34700 nM
The estimate for compound 4 lay 5.6-fold (0.75 log units) below the measured number, and the stated range ends below it.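

In this assay, replacing the 4-methylpiperazin-1-yl group with hydrogen has a much larger effect on the core of compound 3 than on the core of compound 2, with a 6.1-fold higher number from compound 3 to compound 4 (0.78 log units; beyond the scatter) on the former. The same change therefore does not carry a single size from one core to the other, and the two steps differ by more than repeated measurements would explain: the same change on two cores in this assay, a 1.1-fold higher number (0.06 log units; within the scatter) from compound 2 to compound 1 and a 6.1-fold higher number (0.78 log units; beyond the scatter) from compound 3 to compound 4, 5.3-fold (0.73 log units) apart, beyond the scatter of two such steps. This shows that the result of the change depends on the core in these two matched pairs, but two pairs cannot show why, nor predict what the change would do on any third core.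

On these data alone, the two cores differ in more than one place, and which of those differences sets the gap remains open. As far as these compounds go, it is also open whether the same dependence on the core would appear with a morpholine ring or a simple dimethylamino group on that aromatic carbon.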